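Trimming the Amide of Compound 1

A few compounds are considered here, and "the series" means these few. Any claim that something is new, unique, unknown or untested is made for them only; others in the source may bear on it.

Among the measured compounds shown here, compound 1 `CN1CCN(C(=O)/C=C/c2ccncc2-c2ccc3ccccc3c2)CC1` was tested in an assay on a protein complex for inhibition of CDK8/Cyclin C (Homo sapiens), with a stated time of 1 h (a lower number here means a stronger inhibitor, a higher number a weaker inhibitor), where compound 1 gives 43.6 nM, the only number in this set. Compound 2 `COC1CN(C(=O)/C=C/c2ccncc2-c2ccc(F)cc2)C1` was also prepared, but for compound 2 the outcome in this assay is "not determined" (no result reported), so no second reading exists. Compound 3 `NC(=O)/C=C/c1ccncc1-c1ccc2ccccc2c1` differs from compound 1 by amino in place of 4-methylpiperazin-1-yl on a carbonyl carbon. For the measured compounds named here, with no measured step of this kind to lean on, only a modest shift is expected, weakening if anything, and perhaps no further than the usual scatter. Compound 3 is therefore estimated at 65 nM, within 15 nM to 280 nM, which means a step of a 1.5-fold higher number from compound 1 to compound 3 (0.17 log units; within the scatter).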

Compound 3, half-maximal inhibitory concentration: 10.5 nM
Compound 3: the middle estimate sits 6.2-fold (0.79 log units) above what was measured, outside the stated range (below it).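

In this assay, amino in place of 4-methylpiperazin-1-yl on a carbonyl carbon gives a 4.2-fold lower number from compound 1 to compound 3 (0.62 log units; beyond the scatter) and this step lies beyond the scatter. It shows that the six-membered ring is not needed for activity at this position, since the single nitrogen of the carbamoyl group gives the stronger reading. Nothing measured here accounts for this gain. On these data alone, whether a methylamino or dimethylamino group at the same place would keep the gain remains open. So does the outcome of a carboxylic acid in place of the carbamoyl group.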